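A few compounds are considered here, and "the series" means these few. Any claim that something is new, unique, unknown or untested is made for them only; others in the source may bear on it.

Measured compounds:
compound 1 `CCCCCCCCCCCC(=O)OC[C@H](CSC[C@@H](N)C(=O)NCCO)OC(=O)CCCCCCCCCCC` gives 24 nM in an assay on HEK293 cells for agonist activity at Toll-like receptor 2 (Homo sapiens); a lower number here means that less compound is needed, a higher number that more compound is needed for the effect
compound 2 `CCCCCCCCCCCC(=O)OC[C@H](CSC[C@@H](N)C(=O)NCCN)OC(=O)CCCCCCCCCCC` gives 5240 nM in this assay

Within the data shown here, compound 2 stands at the higher of the two numbers; the one step recorded, a 220-fold higher number from compound 1 to compound 2 (2.34 log units; beyond the scatter), separates it from compound 1 and lies well beyond the scatter.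

Compound 3 `CCCCCCCCCCCC(=O)OC[C@H](CSC[C@@H](N)C(=O)NCCCn1ccnc1)OC(=O)CCCCCCCCCCC` has not yet been run in this assay. Its change from compound 2 is (1H-imidazol-1-yl)methyl in place of amino on a saturated chain carbon, two bonds along the chain from an amide-type nitrogen, that is, aminoethyl becomes 3-(1H-imidazol-1-yl)propyl on the amide-type nitrogen.

Only a 220-fold higher number from compound 1 to compound 2 (2.34 log units; beyond the scatter) bears on this position, and it shows that a single exchange of the terminal group on this chain can move the number a long way. The new group shares nothing with either the hydroxy of compound 1 or the amino of compound 2, so the direction cannot be read off that step. The amino leaves, and the amino is what accompanied the large rise from compound 1 to compound 2, so some recovery toward compound 1 is taken as the likelier outcome, with wide uncertainty. The step of a 6.6-fold lower number from compound 2 to compound 3 (0.82 log units; beyond the scatter) is therefore expected to be downward. For compound 3 the estimate in this assay is 800 nM, within 100 nM to 6000 nM.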

Compound 3, half-maximal effective concentration: 410 nM
Compound 3: middle estimate off by 2.0-fold (0.29 log units), on the high side; the range from low to high includes it.
By their numbers in this assay, from the lowest: compound 1; then compound 3; then compound 2.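

In this assay, (1H-imidazol-1-yl)methyl in place of amino gives a 13-fold lower number from compound 2 to compound 3 (1.11 log units; beyond the scatter), so much of the rise seen with the amino group is undone by a change at this same chain carbon, and a ring-bearing group with 0 hydrogen-bond donors is tolerated better than the amino. The recovery is only partial: the same exchange measured against the hydroxy gives a 17-fold higher number from compound 1 to compound 3 (1.23 log units; beyond the scatter), which leaves the hydroxy with the lowest number of the three terminal groups, with each gap beyond the scatter. Nothing available on these compounds accounts for this order of hydroxy, then (1H-imidazol-1-yl)methyl, then amino.

The change from 2-aminoethyl to 3-(1H-imidazol-1-yl)propyl alters both the terminal group and the chain, so the compounds shown do not separate the contribution of the imidazole ring from that of the longer chain; 3-aminopropyl, 3-hydroxypropyl and 2-(1H-imidazol-1-yl)ethyl on the amide-type nitrogen would bear on this. Also open, as far as these compounds go, is how other terminal groups on this chain, such as a carboxylic acid, a methoxy or a dimethylamino group, would rank against the hydroxy.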